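A Diethylamino Change at the Carbonyl Carbon

A few compounds are considered here, and "the series" means these few. Any claim that something is new, unique, unknown or untested is made for them only; others in the source may bear on it.

Of the compounds shown here, three have so far been measured in a functional assay on B16-F10 cells (Mus musculus) for antiproliferative activity, read by MTT assay, with a stated time of 48 h; on this read-out higher numbers stand for weaker inhibition and lower numbers for stronger inhibition. Compound 1 `CCCC(C)Oc1ccc(C(=O)/C=C/c2c(/C=C/c3ccc(OC)cc3)cc(OC)cc2OC)cc1` gives 6.7 ug/mL, compound 2 `COc1ccc(/C=C/c2cc(OC)cc(OC)c2/C=C/C(=O)c2ccccc2C)cc1` gives 6.1 ug/mL, and compound 3 `COc1ccc(/C=C/c2cc(OC)cc(OC)c2/C=C/C(=O)c2ccc(C)cc2C)cc1` gives 4 ug/mL. Compound 3 holds the lowest of the three numbers, but both of its steps stay within the scatter: a 1.5-fold lower number from compound 2 to compound 3 (0.18 log units; within the scatter) and a 1.7-fold lower number from compound 1 to compound 3 (0.22 log units; within the scatter), so the three compounds cannot be separated on these data.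

Compound 4 `CCN(CC)c1ccc(C(=O)/C=C/c2c(/C=C/c3ccc(OC)cc3)cc(OC)cc2OC)cc1` has not yet been measured. It differs from compound 3 in one place: 4-(diethylamino)phenyl in place of 2,4-dimethylphenyl on a carbonyl carbon. The measured steps that bear on this exchange are those that swap the group on the carbonyl carbon, a 1.1-fold lower number from compound 1 to compound 2 (0.04 log units; within the scatter) and a 1.7-fold lower number from compound 1 to compound 3 (0.22 log units; within the scatter), together with the methyl step a 1.5-fold lower number from compound 2 to compound 3 (0.18 log units; within the scatter); every one of them lies within the scatter. None of them brings in a 4-(diethylamino)phenyl, so the expectation rests only on the finding that the groups tried on the carbonyl carbon gave numbers within the scatter of one another. Compound 4 is therefore expected to give 5 ug/mL, with a range from 2 ug/mL to 13 ug/mL. This amounts to an expected step of a 1.3-fold higher number from compound 3 to compound 4 (0.10 log units; within the scatter), not beyond the scatter.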

Compound 4, half-maximal inhibitory concentration: 8.1 ug/mL
For compound 4 the middle estimate is 1.6-fold (0.21 log units) below the measured one, and the stated range covers the measured number.
By their numbers in this assay, from the lowest: compounds 3, 2, 1 and 4 (each within the scatter of the next, the first and the last beyond it).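

Among these compounds, on the carbonyl carbon, 4-(diethylamino)phenyl in place of 2,4-dimethylphenyl gives the first step to pass the scatter in this assay (a 2.0-fold higher number from compound 3 to compound 4 (0.31 log units; beyond the scatter)), though it is only a modest one. The same group stays within the scatter of the other two compounds (a 1.3-fold higher number from compound 2 to compound 4 (0.12 log units; within the scatter)), and so does diethylamino in place of 1-methylbutoxy on an aromatic carbon (a 1.2-fold higher number from compound 1 to compound 4 (0.08 log units; within the scatter)), so only the two ends of the series separate and the four groups span a narrow range. No measurement at hand accounts for this step.

From the compounds shown here alone, it remains open whether a smaller amine such as dimethylamino, or a carboxylic acid, on that aromatic carbon would move the number any further. Nor do the compounds shown tell whether the diethylamino group or the loss of the two methyl groups matters more.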